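A Propargyloxy Swap Carried Onto a Rearranged Core

This account rests on a few compounds, and the source may have more. Where it says the series, first, only, none or still open, it means among the compounds named here.

Compound 1 `COC(=O)CSc1cc(-n2c(=S)n3n(c2=S)CCCC3)c(F)cc1Cl` and compound 3 `COC(=O)CSc1cc(/N=c2\sc(=S)n3n2CCCC3)c(F)cc1Cl` are built from the same atoms joined differently; the difference between the two cores is not broken down here. In a functional assay on the whole organism with Scenedesmus acutus as the target, with a stated time of 20 h (a lower number here means a stronger inhibitor, a higher number a weaker inhibitor), compound 1 gives 158 nM, while compound 3 gives 389 nM, the highest number among the three measured compounds. Compound 2 `C#CCOc1cc(-n2c(=S)n3n(c2=S)CCCC3)c(F)cc1Cl` differs from compound 1 at a single place: propargyloxy in place of ((methoxycarbonyl)methyl)sulfanyl on an aromatic carbon. That change brought a 22-fold lower number from compound 1 to compound 2 (1.34 log units; beyond the scatter), and in this assay compound 2 gives 7.24 nM, the lowest number of the set.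

Compound 4 `C#CCOc1cc(/N=c2\sc(=S)n3n2CCCC3)c(F)cc1Cl` stands to compound 3 as compound 2 stands to compound 1: propargyloxy in place of ((methoxycarbonyl)methyl)sulfanyl on an aromatic carbon. The surroundings of the place are described in identical terms for both pairs, so this is the same change, now made on the rearranged core. Among the compounds with values here, no measured pair yet shows how that core answers a change at this position, so the expectation rests on the one step seen. The step from compound 3 to compound 4 is expected to be an 18-fold lower number from compound 3 to compound 4 (1.25 log units; beyond the scatter) in this assay, somewhat smaller than the measured one because a 22-fold lower number from compound 1 to compound 2 (1.34 log units; beyond the scatter) rests on a single pair and the core of compound 3 is not the core of compound 1. Compound 4 is therefore estimated at 22 nM in this assay, expected to fall between 7 nM and 70 nM.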

Compound 4, half-maximal inhibitory concentration: 79.4 nM
Estimate against measurement, compound 4: 3.6-fold (0.56 log units) below; the measured number lies above the stated range.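

On the rearranged core the swap again lowered the number in this assay, with a 4.9-fold lower number from compound 3 to compound 4 (0.69 log units; beyond the scatter), so the direction of the change carried over from one core to the other. Its size did not carry over, and the two steps stand apart by more than their scatter: the same change on two cores in this assay, a 22-fold lower number (1.34 log units; beyond the scatter) from compound 1 to compound 2 and a 4.9-fold lower number (0.69 log units; beyond the scatter) from compound 3 to compound 4, 4.5-fold (0.65 log units) apart, beyond the scatter of two such steps With a single pair on each core, this shows that propargyloxy in place of ((methoxycarbonyl)methyl)sulfanyl lowered the number on both cores by unequal amounts, but it does not show why the cores answer differently, nor whether the same gap would appear with any other change at this place.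

The compounds shown leave open how other groups on this aromatic carbon would behave on the two cores, for instance a methoxy group, an allyloxy group, a longer alkynyl ether chain or a carboxylic acid in place of the methyl ester. They also leave open whether the gap between the cores would persist if the chloro or fluoro group on the aromatic ring were replaced, for instance by a bromo group or a hydrogen.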